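This account rests on a few compounds, and the source may have more. Where it says the series, first, only, none or still open, it means among the compounds named here.

Measured compounds and their inhibition of paw edema:

compound 1 `O=C(N/N=C/c1ccccc1)c1cccnc1Nc1cccc(C(F)(F)F)c1` — 53.9%
compound 2 `O=C(N/N=C/c1ccc(O)cc1)c1cccnc1Nc1cccc(C(F)(F)F)c1` — 70.5%
compound 3 `COc1cccc(/C=N/NC(=O)c2cccnc2Nc2cccc(C(F)(F)F)c2)c1` — 58.8%

In a functional assay on the whole organism (strain Wistar) for inhibition, with Rattus norvegicus as the target, read by paw edema, with a stated time of 1 h, at a dose of 10 mg/kg by the intraperitoneal route (on this read-out lower numbers stand for less inhibition and higher numbers for more inhibition at the one dose given (going by the name of the read-out)), compound 3 stands second highest of the three numbers. Its nearest neighbour is compound 1, from which it differs by a number 4.9 percentage points higher from compound 1 to compound 3 (within the scatter), a step that does not rise above the scatter. Its furthest neighbour is compound 2, and the step of a number 11.7 percentage points lower from compound 2 to compound 3 (beyond the scatter) is modest but beyond the scatter.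

Compound 4 `CN(C)c1ccc(/C=N/NC(=O)c2cccnc2Nc2cccc(C(F)(F)F)c2)cc1` is not yet measured. It differs from compound 3 in one place: 4-(dimethylamino)phenyl in place of 3-methoxyphenyl on a carbon with a double bond to nitrogen. No measured step introduces a dimethylamino group, so the expectation must rest on what the ring substituents so far have shown. The hydroxy step a number 16.6 percentage points higher from compound 1 to compound 2 (beyond the scatter) gave the largest rise seen; the methoxy step a number 4.9 percentage points higher from compound 1 to compound 3 (within the scatter) stayed within the scatter. Both substituted compounds sit at or above compound 1, so a fall below compound 3 seems the less likely outcome, and a modest rise is the most reasonable guess, though it may well remain within the scatter.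

Compound 4 is therefore expected to give 62%, with a range from 48% to 76%. The expected step from compound 3 is a number 3.2 percentage points higher from compound 3 to compound 4 (within the scatter).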

Compound 4, a percentage reported as inhibition, in the whole organism at one dose (the size of the read-out at that dose, not a potency): 63.5%
Compound 4: the middle estimate sits 1.5 percentage points below what was measured, and the stated range covers the measured number.
By their numbers in this assay, from the lowest: compounds 1, 3, 4 and 2 (each within the scatter of the next, the first and the last beyond it).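

In this assay, replacing 3-methoxyphenyl with 4-(dimethylamino)phenyl on the carbon with a double bond to nitrogen gives a number 4.7 percentage points higher from compound 3 to compound 4 (within the scatter), so the two groups cannot be told apart on this read-out. Dimethylamino in place of hydroxy gives a number 7 percentage points lower from compound 2 to compound 4 (within the scatter), and dimethylamino in place of hydrogen gives a number 9.6 percentage points higher from compound 1 to compound 4 (within the scatter), so compound 4 cannot be separated from either, although a number 16.6 percentage points higher from compound 1 to compound 2 (beyond the scatter) does separate the two compounds at the ends of the series. Until now only the hydroxy group had stood apart from hydrogen here, and the nitrogen-bearing group of compound 4 now fills the gap between them without being distinguishable from either end.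

No measurement given here bears on what lies behind these small differences. Going by these compounds alone, it also remains open whether a carboxylic acid or a longer chain on this ring would clearly separate from hydrogen or hydroxy, and whether the ordering would hold at other doses or times, since each compound has only one reading.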